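Methoxy in Place of Fluoro on the Benzamide Ring

The compounds below may be only part of what the source reports. "The series", "measured", "known", "first", "only" and "open" are said of these compounds alone.

Compound 1 `CN(c1ccccc1)S(=O)(=O)c1ccc(NC(=O)c2ccc(Cl)cc2Cl)cc1`: 2570 nM
Compound 2 `O=C(Nc1ccc(S(=O)(=O)Nc2ccccc2)cc1)c1cc2ccccc2oc1=O`: 7760 nM
Compound 3 `O=C(Nc1ccc(S(=O)(=O)Nc2ccccc2)cc1)c1ccc(Br)cc1F`: 479 nM

All three were tested in a functional assay on HEK293 cells for agonist activity at probable G-protein coupled receptor 27 (Homo sapiens), read by a luciferase reporter and beta-arrestin recruitment, with a stated time of 10 min; a higher number here means that more compound is needed for the effect, a lower number that less compound is needed. Compound 3 gives the lowest number of the three; compound 1 sits higher by a gap beyond the usual scatter, and compound 2 higher still. Compound 4 `COc1cc(Br)ccc1C(=O)Nc1ccc(S(=O)(=O)Nc2ccccc2)cc1` has not yet been tested. It differs from compound 3 in one place: methoxy in place of fluoro on an aromatic carbon. Among the measured compounds shown here, no two tested compounds differ in only one place, so there is no measured step to lean on. The step from compound 3 to compound 4 in this assay is expected to be modest, most likely a small rise that may stay within the scatter. Compound 4 is therefore expected to give about 800 nM, somewhere between 250 nM and 2500 nM, which means an expected step of a 1.7-fold higher number from compound 3 to compound 4 (0.22 log units; within the scatter).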

Compound 4, half-maximal effective concentration: 1020 nM
Estimate against measurement, compound 4: 1.3-fold (0.11 log units) below; the range from low to high includes it.
By their numbers in this assay, from the lowest: compound 3; then compound 4; then compound 1; then compound 2.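

Swapping fluoro for methoxy, that is, going from 4-bromo-2-fluorophenyl to 4-bromo-2-methoxyphenyl, gives the first single-change reading in this assay, with a 2.1-fold higher number from compound 3 to compound 4 (0.33 log units; beyond the scatter). The change is modest but beyond the scatter, so this aromatic carbon does affect the result, and methoxy still leaves compound 4 with a measurable effect. Nothing measured here explains the rise.

Going by these compounds, whether a hydroxyl, an amine or a methyl on this carbon would give a lower or higher number remains open. So does whether the same swap would have a similar effect in compounds without the bromo group.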